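A few compounds are considered here, and "the series" means these few. Any claim that something is new, unique, unknown or untested is made for them only; others in the source may bear on it.

Compound 1 `O=C(Nc1nc2ccc(Cl)cc2s1)c1cn(-c2ccccc2)nc1-c1ccc(F)cc1` was examined in an ADME assay on HEK-293T cells (Homo sapiens) for cytotoxicity, read by MTT assay, with a stated time of 72 h (on this read-out higher numbers stand for weaker inhibition and lower numbers for stronger inhibition), where compound 1 gives 45700 nM. Compound 3 `O=C(Nc1nc2ccc(Cl)cc2s1)c1cn(-c2ccccc2)nc1-c1ccc(Cl)cc1` differs from compound 1 by chloro in place of fluoro on an aromatic carbon, and in this assay compound 3 gives 15700 nM. This amounts to a 2.9-fold lower number from compound 1 to compound 3 (0.46 log units; beyond the scatter), so compound 3 holds the lower of the two numbers.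

Compound 2 `COc1ccc2nc(NC(=O)c3cn(-c4ccccc4)nc3-c3ccc(F)cc3)sc2c1` carries methoxy in place of chloro on an aromatic carbon relative to compound 1. In this assay compound 2 reaches only the limit of the assay, > 50000 nM, so no number is known for it. The change from compound 1 to compound 2 therefore reads as an at least 1.0-fold higher number from compound 1 to compound 2 (0.03 log units; that floor lies within the scatter), with the floor set by the limit of > 50000 nM in this assay, at which 1 of the 3 values shown sits.

Compound 4 `COc1ccc2nc(NC(=O)c3cn(-c4ccccc4)nc3-c3ccc(Cl)cc3)sc2c1` has not yet been measured in this assay. It differs from compound 3 by methoxy in place of chloro on an aromatic carbon, the same change already seen from compound 1 to compound 2, now made on a core that differs by chloro in place of fluoro on an aromatic carbon. On the strength of compound 2 and an at least 1.0-fold higher number from compound 1 to compound 2 (0.03 log units; that floor lies within the scatter), compound 4 is expected to give a higher number than compound 3, an expected step of a 2.5-fold higher number from compound 3 to compound 4 (0.41 log units; beyond the scatter). Because compound 2 sat at the limit of > 50000 nM in this assay, at which 1 of the 3 values shown sits, the size of the earlier step is itself uncertain, and compound 4 may likewise end at the limit rather than a number. The estimate for compound 4 in this assay is 40000 nM, expected to fall between 15000 nM and 100000 nM.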

Compound 4, half-maximal inhibitory concentration: 29600 nM
For compound 4 the middle estimate is 1.4-fold (0.13 log units) above the measured one; the range from low to high includes it.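

In this assay, methoxy in place of chloro on an aromatic carbon gives a 1.9-fold higher number from compound 3 to compound 4 (0.28 log units; within the scatter), and this step can be set beside the same change on the core of compound 1 only through a limit: the same change on two cores in this assay, an at least 1.0-fold higher number (0.03 log units; that floor lies within the scatter) from compound 1 to compound 2 and a 1.9-fold higher number (0.28 log units; within the scatter) from compound 3 to compound 4; the limit leaves it open whether they differ. The change of chloro in place of fluoro on an aromatic carbon, read on the methoxy core, gives an at least 1.6-fold lower number from compound 2 to compound 4 (0.22 log units; that floor lies within the scatter), and the comparison with its earlier step meets the same obstacle: the same change on two cores in this assay, a 2.9-fold lower number (0.46 log units; beyond the scatter) from compound 1 to compound 3 and an at least 1.6-fold lower number (0.22 log units; that floor lies within the scatter) from compound 2 to compound 4; the limit leaves it open whether they differ. The two pairs therefore show neither that each change carries over from one core to the other with the same size nor that its size depends on the core, because compound 2 stands at a limit of the assay and not at a number: the limit of > 50000 nM in this assay, at which 1 of the 4 values shown sits.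

The compounds shown leave open the true size of both steps that start or end at compound 2, and so whether the two changes simply add on these cores. They also leave open how an amine, a carboxylic acid or a longer chain on the same aromatic carbon, in place of the chloro or the methoxy, would read in this assay.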